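This account rests on a few compounds, and the source may have more. Where it says the series, first, only, none or still open, it means among the compounds named here.

Series notes. Compound 1 `CCN1CCN(c2c(CO)c(=O)oc3ccccc23)CC1`, compound 2 `O=c1oc2ccccc2c(N2CCN(c3ccc(F)cc3)CC2)c1CO` and compound 3 `O=c1oc2ccccc2c(N2CCN(c3ccc(Cl)c(Cl)c3)CC2)c1CO` share one core and differ only at an amine nitrogen in a ring. In a toxicity assay on HEK-293T cells (Homo sapiens) for inhibition, read by MTT assay, with a stated time of 24 h (a lower number here means that less compound is tolerated, a higher number that more compound is tolerated), compound 1 gives only a limit, > 50000 nM. In this assay compound 2 likewise gives a limit, > 50000 nM. Compound 3 also gives a limit, > 50000 nM. Of the measured steps, a step that the two limits leave unreadable from compound 1 to compound 2, a step that the two limits leave unreadable from compound 1 to compound 3 and a step that the two limits leave unreadable from compound 2 to compound 3 yield no readable size, since (the limit of > 50000 nM in this assay, at which 3 of the 3 values shown sit). Compound 4 `O=c1oc2ccccc2c(N2CCN(c3cccc(Cl)c3)CC2)c1CO` differs from compound 3 by hydrogen in place of chloro on an aromatic carbon. Within the data shown here, no measured step therefore bears on this change with a readable size, and a limit is again the likely outcome. Compound 4 is expected at 60000 nM, between 20000 nM and 200000 nM, with a step that the limit leaves unreadable from compound 3 to compound 4 expected to be none beyond the scatter.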

Compound 4, half-maximal cytotoxic concentration: > 50000 nM
Compound 4 was reported as a limit; the forecaster's own chance of this, stated with the estimate: 80%; the middle value lies beyond the limit too.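

Compound 4 gives only a limit in this assay, so its steps from compound 1, compound 2 and compound 3 cannot be read: the limit of > 50000 nM in this assay, at which 4 of the 4 values shown sit. The compounds shown leave open whether any change at the amine nitrogen or on the aromatic ring alters tolerance in this assay at all.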